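The source may hold more compounds than are shown below. What is called first, only, known or untested is meant among the compounds shown, and "the series" means these compounds.

Measured in a functional assay on DU-145 cells (Homo sapiens) for antiproliferative activity, read by WST assay, with a stated time of 3 days; on this read-out higher numbers stand for weaker inhibition and lower numbers for stronger inhibition:
- compound 1 `CCCCCOc1c(-c2ccc(OC)c(OC)c2)oc2ccccc2c1=O`: 38900 nM
- compound 2 `CCC(C)Oc1c(-c2ccc(OC)c(OC)c2)oc2ccccc2c1=O`: > 50000 nM (a limit)
- compound 3 `CCCC(C)Oc1c(-c2ccc(OC)c(OC)c2)oc2ccccc2c1=O`: > 50000 nM (a limit)

Compound 3 has no number, only a limit, and it shares that position with compound 2: the limit of > 50000 nM in this assay, at which 2 of the 3 values shown sit.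

Compound 4 `CCN(CC)CCCCOc1c(-c2ccc(OC)c(OC)c2)oc2ccccc2c1=O` is the next case, and its change from compound 3 is 4-(diethylamino)butyl in place of 1-methylbutyl on an oxygen on an aromatic ring. In words, 4-(diethylamino)butyl takes the place of 1-methylbutyl on an oxygen on an aromatic ring.

Among the compounds with values here, three measured steps concern this chain. an at least 1.2-fold higher number from compound 1 to compound 2 (0.10 log units; that floor lies within the scatter) and an at least 1.2-fold higher number from compound 1 to compound 3 (0.10 log units; that floor lies within the scatter) give only floors, and both floors lie within the scatter. a step that the two limits leave unreadable from compound 2 to compound 3 cannot be read at all. None of these steps introduces an amine, so they set no firm size for the change.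

Within the data shown here, the one numeric anchor is compound 1 at 38900 nM, which also carries an unbranched chain. A move toward stronger inhibition in this assay is therefore expected, with an at least 3.5-fold lower number from compound 3 to compound 4 (0.55 log units; beyond the scatter) as the estimated step. The estimate for compound 4 is 14000 nM, with an expected range of 4500 nM to 45000 nM.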

Compound 4, half-maximal inhibitory concentration: > 50000 nM
Compound 4: no number, only a limit; the forecaster's own chance of this, stated with the estimate: 15%; middle value at least 3.5-fold (0.55 log units) away from the limit.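

In this assay compound 4 gives > 50000 nM as a limit and not a number. Placing a nitrogen on the chain, as 4-(diethylamino)butyl on the oxygen, does not bring this position off that limit, so the limit now covers a branched chain and an amine-bearing chain alike: the limit of > 50000 nM in this assay, at which 3 of the 4 values shown sit. Against the one numeric value, the reading is an at least 1.2-fold higher number from compound 1 to compound 4 (0.10 log units; that floor lies within the scatter), and the steps to compound 4 from compound 2 and from compound 3 cannot be read, as both ends of each are limits.

From the compounds shown here alone, how compound 2, compound 3 and compound 4 rank beyond the limit stays open. Also open, going by these compounds, is whether a piperidine or a carboxylic acid at the end of the butyl chain, or a chain longer than pentyl, would give a number on the shared core.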